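This account rests on a few compounds, and the source may have more. Where it says the series, first, only, none or still open, it means among the compounds named here.

Compound 1 `COc1cc(Nc2nc3ccccc3nc2S(=O)(=O)c2ccc(C)cc2)cc(OC)c1` gives in a functional assay on HCT-116 cells (Homo sapiens) for cytotoxicity, read by MTT assay, with a stated time of 72 h (on this read-out lower numbers stand for stronger inhibition and higher numbers for weaker inhibition), only a limit, > 50000 nM. Compound 2 `Cc1ccc(S(=O)(=O)c2nc3ccccc3nc2Nc2cccc(O)c2)cc1` gives in this assay 3810 nM. Within the data shown here, the one measured step, an at least 13-fold lower number from compound 1 to compound 2 (1.11 log units; beyond the scatter), changes the group on the nitrogen and leaves the sulfonyl side untouched. Compound 3 `COc1cc(Nc2nc3ccccc3nc2S(=O)(=O)c2ccc(F)cc2)cc(OC)c1` differs from compound 1 in that other part, by fluoro in place of methyl on an aromatic carbon. Among the measured compounds shown here, no measured step bears on this change, and compound 1 sits at the limit of > 50000 nM in this assay, at which 1 of the 2 values shown sits. For compound 3 the step of a number no higher from compound 1 to compound 3 (the limit leaves the size open) is therefore expected to be none beyond the scatter. Compound 3 is estimated at 50000 nM, between 15000 nM and 150000 nM.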

Compound 3, half-maximal inhibitory concentration: 3930 nM
Compound 3: the middle estimate sits 13-fold (1.10 log units) above what was measured, and the stated range ends above it.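

In this assay, the step of an at least 12-fold lower number from compound 1 to compound 3 (1.10 log units; beyond the scatter) shows that the sulfonyl side matters too: with the 3,5-dimethoxyphenyl group kept, fluoro in place of methyl is enough to give a measured number. Until now, only a change to the group on the nitrogen had been seen to do this. The true size of the step stays open, as compound 1 gives only a limit: the limit of > 50000 nM in this assay, at which 1 of the 3 values shown sits.

Still open, as far as these compounds go, is whether fluoro does the same alongside the 3-hydroxyphenyl group of compound 2. Also open, from the compounds shown here alone, is how chloro, an amine or a carboxylic acid would fare in that place.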